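A few compounds are considered here, and "the series" means these few. Any claim that something is new, unique, unknown or untested is made for them only; others in the source may bear on it.

For the measured compounds named here, compound 1 `NC(=O)CCn1nc(-c2ccccc2)ccc1=O` has the lowest number of the three measured members: in a functional assay on the whole organism (stomach) for inhibition, with Rattus norvegicus as the target, at a dose of 100 mg/kg by the intraduodenal route (a lower number here means less inhibition, a higher number more inhibition at the dose given (going by the name of the read-out)), compound 1 gives -2.8%, the lowest of the three numbers, with compound 2 nearest and compound 3 furthest, both beyond the scatter. Going by the values given here, compound 2 `CC(CC(=N)S)n1nc(-c2ccccc2)ccc1=O` gives 15.5% and compound 3 `COc1ccc(-c2ccc(=O)n(CCC(=N)S)n2)cc1` gives 20.7%; no single-place step links compound 3 to the others, so only its value stands.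

Compound 4 `CN(C)C(=S)CCn1nc(-c2ccccc2)ccc1=O` differs from compound 1 in one place: a group of 5 heavy atoms (3 carbon, 1 nitrogen, 1 sulfur; no ring) in place of a group of 3 heavy atoms (1 carbon, 1 nitrogen, 1 oxygen; no ring), on a saturated chain carbon, two bonds along the chain from an aromatic nitrogen.

Among the compounds with values here, the one measured step that bears on this is a number 18.3 percentage points higher from compound 1 to compound 2 (beyond the scatter), where the chain on the aromatic nitrogen likewise loses its carbamoyl in favour of a sulfur-bearing group. That step was modest and upward. The change to compound 4 is of the same kind but sits on the chain carbon rather than rebuilding the whole chain, so a step of similar or somewhat smaller size upward is expected in this assay. Compound 4 is therefore estimated at 12%, within 0% to 25%, an expected step of a number 14.8 percentage points higher from compound 1 to compound 4 (beyond the scatter).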

Compound 4, a percentage reported as inhibition, in the whole organism at one dose (the size of the read-out at that dose, not a potency): 46%
For compound 4 the middle estimate is 34 percentage points below the measured one; the whole stated range lies below it.
By their numbers in this assay, from the lowest: compound 1; then compounds 2 and 3 (each within the scatter of the next); then compound 4.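

In this assay, the change at the saturated chain carbon, two bonds along the chain from an aromatic nitrogen, gives a number 48.8 percentage points higher from compound 1 to compound 4 (beyond the scatter), a large step, whereas the earlier step gave a number 18.3 percentage points higher from compound 1 to compound 2 (beyond the scatter) and was only modest. For the compounds shown here, this position therefore accepts the group of 5 heavy atoms with its sulfur, which has 0 hydrogen-bond donors in place of the 1 on carbamoyl, and the read-out responds far more strongly here than the earlier compounds indicated. No available measurement accounts for the size of this step.

Still open, as far as these compounds go, is whether the gain follows the sulfur or the two methyl groups on the nitrogen, which a dimethylcarbamoyl group at this place would separate. Also open, from the compounds shown here alone, is how a carboxylic acid or a longer chain would read at the same position.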